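Swapping Trifluoromethyl for Hydroxy on a Shared Core

A few compounds are considered here, and "the series" means these few. Any claim that something is new, unique, unknown or untested is made for them only; others in the source may bear on it.

Of the compounds shown here, three built on one shared core have been tested in a functional assay on A549 cells (Homo sapiens) for antiproliferative activity, read by MTT assay, with a stated time of 72 h; on this read-out lower numbers stand for stronger inhibition and higher numbers for weaker inhibition. Compound 1 `COc1ccc(-c2ccc3ncn(-c4cc(OC)c(OC)c(OC)c4)c3c2)cc1F` gives 1430 nM, compound 2 `COc1cc(-n2cnc3ccc(-c4ccc(C(F)(F)F)cc4)cc32)cc(OC)c1OC` gives 3390 nM, and compound 3 `COc1cc(-n2cnc3ccc(-c4cccc(F)c4)cc32)cc(OC)c1OC` gives 5270 nM. On these numbers compound 2 stands between the other two: the step of a 2.4-fold higher number from compound 1 to compound 2 (0.37 log units; beyond the scatter) lies beyond the scatter, while the step of a 1.6-fold higher number from compound 2 to compound 3 (0.19 log units; within the scatter) stays within it.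

Compound 4 `COc1cc(-n2cnc3ccc(-c4ccc(O)cc4)cc32)cc(OC)c1OC` has not yet been measured. It differs from compound 2 by hydroxy in place of trifluoromethyl on an aromatic carbon. Going by the values given here, two measured steps bear on this change. The removal of a methoxy, a 3.7-fold higher number from compound 1 to compound 3 (0.57 log units; beyond the scatter), shows that a methoxy at this part of the molecule goes with a lower number, and the exchange a 2.4-fold higher number from compound 1 to compound 2 (0.37 log units; beyond the scatter) places the trifluoromethyl compound above the methoxy-bearing compound 1. Among the compounds with values here, no measured pair exchanges trifluoromethyl for hydroxy directly, so the size of the coming step remains uncertain. A modest move toward a lower number is therefore expected for compound 4, a 1.4-fold lower number from compound 2 to compound 4 (0.13 log units; within the scatter). The estimate for compound 4 in this assay is 2500 nM, with an expected range from 900 nM to 7000 nM.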

Compound 4, half-maximal inhibitory concentration: 5090 nM
Beside the measured number, compound 4's estimate is 2.0-fold (0.31 log units) below it; measured number inside the range.
By their numbers in this assay, from the lowest: compound 1; then compounds 2, 4 and 3 (each within the scatter of the next).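

In this assay the exchange of trifluoromethyl for hydroxy, on an aromatic carbon para to a large group, gives a 1.5-fold higher number from compound 2 to compound 4 (0.18 log units; within the scatter) and so cannot be told apart from no change, although a group with no hydrogen-bond donor gives way to one with a hydrogen-bond donor. The 4-hydroxyphenyl compound likewise cannot be separated from the 3-fluorophenyl compound, with a 1.0-fold lower number from compound 3 to compound 4 (0.02 log units; within the scatter), whereas a 3.6-fold higher number from compound 1 to compound 4 (0.55 log units; beyond the scatter) adds a third step beyond the scatter, leaving compound 1 with the lowest number of the four and compounds 2, 3 and 4 as the group above it. Nothing at hand explains why these different groups read alike here.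

The four compounds leave open whether an amine or a carboxylic acid on the same aromatic carbon would also stay with compounds 2, 3 and 4 or would come closer to compound 1. Going by these compounds alone, they also leave open how much of the lower number of compound 1 goes with its methoxy and how much with its fluorine, since no compound here carries a 4-methoxyphenyl group alone.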